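Benzyl replaces aminopropyl on the thioether of compound 2

The source may hold more compounds than are shown below. What is called first, only, known or untested is meant among the compounds shown, and "the series" means these compounds.

Measured so far:
compound 1 `CC(C)Oc1nc(C(C)(C)C)ccc1CNC(=O)C(C)c1ccc(NS(C)(=O)=O)c(F)c1` 2.3 nM
compound 2 `CC(C(=O)NCc1ccc(C(C)(C)C)nc1SCCCN1CCCC1)c1ccc(NS(C)(=O)=O)c(F)c1` 17.1 nM

Within the data shown here, in an assay on cells for antagonist activity at transient receptor potential cation channel subfamily V member 1 (Homo sapiens), read by FLIPR and calcium flux, with a stated time of 6 min (a higher number here means a weaker inhibitor, a lower number a stronger inhibitor), compound 2 gives 17.1 nM, the higher of the two numbers so far; its nearest neighbour is compound 1, and a 7.4-fold higher number from compound 1 to compound 2 (0.87 log units; beyond the scatter). Compound 3 `CC(C(=O)NCc1ccc(C(C)(C)C)nc1SCc1ccccc1)c1ccc(NS(C)(=O)=O)c(F)c1` is not yet measured. It differs from compound 2 in one place: phenyl in place of 2-(pyrrolidin-1-yl)ethyl on a saturated chain carbon bound to a sulfur. Among the measured compounds shown here, the one measured step, from compound 1 to compound 2, swapped the whole substituent on the aromatic carbon and is modest in size; it does not touch the terminus of the chain that changes here, so no measured step bears directly on this change. It only shows that this part of the molecule tolerates a change without more than a modest shift. Compound 3 is therefore expected to stay near compound 2, with a small step of uncertain direction, a 1.7-fold lower number from compound 2 to compound 3 (0.23 log units; within the scatter). The estimate for compound 3 in this assay is 10 nM, with a range from 2.5 nM to 40 nM.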

Compound 3, inhibition constant: 4 nM
For compound 3 the middle estimate is 2.5-fold (0.40 log units) above the measured one, within the range that was stated.
By their numbers in this assay, from the lowest: compounds 1 and 3 (each within the scatter of the next); then compound 2.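

In this assay, the end of the sulfur-linked chain proves to matter: phenyl in place of 2-(pyrrolidin-1-yl)ethyl on a saturated chain carbon bound to a sulfur gives a 4.3-fold lower number from compound 2 to compound 3 (0.63 log units; beyond the scatter), which shows that the weaker number of compound 2 is not shared by every group attached through sulfur. Benzylsulfanyl in place of isopropoxy on an aromatic carbon gives a 1.7-fold higher number from compound 1 to compound 3 (0.24 log units; within the scatter), and the two compounds cannot be told apart here. Nothing measured here explains the difference between the two sulfur-linked groups.

From the compounds shown here alone, whether the step from compound 2 to compound 3 follows from the entering phenyl or from the departing pyrrolidine remains open. A plain methylsulfanyl group, or a dimethylamine ending the propyl chain, would help separate the two.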